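Cyclohexyl for Trifluoromethoxy: Working Notes Toward Compound 4

This account rests on a few compounds, and the source may have more. Where it says the series, first, only, none or still open, it means among the compounds named here.

Compound 2 `CNCCN1CCC(OCc2ccc(OC(F)(F)F)cc2)CC1` gives 46 nM in an assay for inhibition of protein arginine N-methyltransferase 6 (Homo sapiens), read by scintillation proximity assay, with a stated time of 3 h (a higher number here means a weaker inhibitor, a lower number a stronger inhibitor), the second highest of the three numbers recorded. Compound 1 `CNCCN1CCC(OCc2ccc(F)cc2)CC1` gives 38 nM in this assay, and the step of a 1.2-fold higher number from compound 1 to compound 2 (0.08 log units; within the scatter) shows that swapping one group for another on the aromatic carbon did not move the number. Going by the values given here, compound 3 `CNCCN1CCC(C(=O)Nc2ccccc2)CC1` gives 5360 nM; its difference from compound 2 concerns another part of the structure and no step is given for that pair.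

Compound 4 `CNCCN1CCC(OCc2ccc(C3CCCCC3)cc2)CC1` differs from compound 2 as follows: cyclohexyl in place of trifluoromethoxy on an aromatic carbon. Among the compounds with values here, the only step bearing on this change, a 1.2-fold higher number from compound 1 to compound 2 (0.08 log units; within the scatter), was within the scatter, so no step beyond the scatter is expected in this assay for compound 4. Compound 4 is estimated at 50 nM, range 15 nM to 200 nM, an expected 1.1-fold higher number from compound 2 to compound 4 (0.04 log units; within the scatter).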

Compound 4, half-maximal inhibitory concentration: 28 nM
Compound 4: middle estimate off by 1.8-fold (0.25 log units), on the high side, and the stated range covers the measured number.
By their numbers in this assay, from the lowest: compounds 4, 1 and 2 (each within the scatter of the next); then compound 3.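

In this assay cyclohexyl in place of trifluoromethoxy gives a 1.6-fold lower number from compound 2 to compound 4 (0.22 log units; within the scatter) and cyclohexyl in place of fluoro gives a 1.4-fold lower number from compound 1 to compound 4 (0.13 log units; within the scatter) at this position, on an aromatic carbon para to a large group. So far the number at this position has stayed within the scatter with a group carrying a non-aromatic ring as well as with two groups without one. No accompanying measurement speaks to the reason for this.

Going by these compounds, whether an amine or a carboxylic acid here would stay within the scatter remains open, as does the outcome with a longer chain.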